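Methyl in Place of Fluoro on the Aryl Ring

This account rests on a few compounds, and the source may have more. Where it says the series, first, only, none or still open, it means among the compounds named here.

Three compounds share one core and differ only in the substituents on the aromatic ring at one end. Compound 1 `COc1ccc(/C=C/C(=O)/C=C/C2=C(C)CCCC2(C)C)cc1O` carries a hydroxy and a methoxy group; in a functional assay on LNCaP cells (Homo sapiens) for cytotoxicity, read by MTT assay, with a stated time of 72 h (on this read-out higher numbers stand for weaker inhibition and lower numbers for stronger inhibition), compound 1 gives 9900 nM. Compound 2 `COc1ccc(/C=C/C(=O)/C=C/C2=C(C)CCCC2(C)C)cc1OC` carries two methoxy groups; in this assay compound 2 gives 9500 nM. The step of a 1.0-fold lower number from compound 1 to compound 2 (0.02 log units; within the scatter) shows that this exchange left the number essentially unchanged. Compound 3 `CC1=C(/C=C/C(=O)/C=C/c2cccc(F)c2)C(C)(C)CCC1` carries a single fluoro group; in this assay compound 3 gives 12900 nM. Compound 3 sits at the upper end of a narrow band in which all three numbers lie within the scatter of one another, so none of the three can be called stronger or weaker than the others.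

Compound 4 `CC1=C(/C=C/C(=O)/C=C/c2cccc(C)c2)C(C)(C)CCC1` differs from compound 3 by methyl in place of fluoro on an aromatic carbon. Among the compounds with values here, no measured step involves this particular exchange; the one step available, a 1.0-fold lower number from compound 1 to compound 2 (0.02 log units; within the scatter), concerns oxygen-bound substituents and was within the scatter. With no evidence that small changes on this ring move the number, the step of a 1.1-fold lower number from compound 3 to compound 4 (0.03 log units; within the scatter) is expected to stay within the scatter. Compound 4 is therefore estimated at 12000 nM, within a range from 5000 nM to 30000 nM.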

Compound 4, half-maximal inhibitory concentration: 17800 nM
For compound 4 the middle estimate is 1.5-fold (0.17 log units) below the measured one; measured number inside the range.
By their numbers in this assay, from the lowest: compounds 2, 1, 3 and 4 (each within the scatter of the next).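

In this assay, within the data shown here, the step of a 1.4-fold higher number from compound 3 to compound 4 (0.14 log units; within the scatter) is the first direct reading of the change from 3-fluorophenyl to 3-methylphenyl, and it does not separate the two compounds. The earlier step concerned a group on an oxygen, whereas this one replaces a group sitting directly on an aromatic carbon, meta to a large group, and here too the difference lies within the usual scatter of repeated measurements, so no order can be set between compound 3 and compound 4. The data shown offer no independent measurement that could explain this result or say what either group does in the cells.

As far as these compounds go, the two groups compared here each have a single heavy atom, so it remains open whether something quite different at this place, such as an amine, a carboxylic acid or a longer chain, would move the number beyond the scatter. From the compounds shown here alone, it also remains open whether fluoro and methyl would stay as close together elsewhere on the ring, or on a different core from the one shared here.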